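From 3-bromophenyl to 4-methoxyphenyl on the shared core

The compounds below may be only part of what the source reports. "The series", "measured", "known", "first", "only" and "open" are said of these compounds alone.

In a functional assay (on this read-out higher numbers stand for weaker inhibition and lower numbers for stronger inhibition), the measured compounds stand as follows:

Compound 1 `CC(C)=CCOc1cc(O)c2c(c1)OC(c1cccc(F)c1)CC2=O` gives 7240 nM
Compound 2 `CC(C)=CCOc1cc(O)c2c(c1)OC(c1ccc(Cl)cc1)CC2=O` gives 7020 nM
Compound 3 `CC(C)=CCOc1cc(O)c2c(c1)OC(c1cccc(Br)c1)CC2=O` gives 4040 nM

Compound 3 stands at 4040 nM and lies within the scatter of the other two, with a 1.8-fold lower number from compound 1 to compound 3 (0.25 log units; within the scatter) and a 1.7-fold lower number from compound 2 to compound 3 (0.24 log units; within the scatter) as its steps. Compound 4 `COc1ccc(C2CC(=O)c3c(O)cc(OCC=C(C)C)cc3O2)cc1` has 4-methoxyphenyl in place of 3-bromophenyl on a saturated ring carbon next to the ring oxygen. The measured exchanges of the group on this carbon bear on the change, and the third of them is a 1.0-fold lower number from compound 1 to compound 2 (0.01 log units; within the scatter) in size. Among the measured compounds shown here, no measured compound carries a methoxy group, so that group itself is untested here. All three steps stayed within the scatter, so no step beyond the scatter is expected in this assay and no direction can be firmly expected. The estimated change is a 1.4-fold higher number from compound 3 to compound 4 (0.13 log units; within the scatter) and is expected to stay small. Compound 4 is expected at 5500 nM with an estimated range from 2500 nM to 12000 nM on this read-out.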

Compound 4, half-maximal inhibitory concentration: 5080 nM
For compound 4 the middle estimate is 1.1-fold (0.03 log units) above the measured one; low and high end bracket the measured number.
By their numbers in this assay, from the lowest: compounds 3, 4, 2 and 1 (each within the scatter of the next).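

In this assay the exchange of 3-bromophenyl, with 0 hydrogen-bond acceptors, for 4-methoxyphenyl, with 1 hydrogen-bond acceptor, gives a 1.3-fold higher number from compound 3 to compound 4 (0.10 log units; within the scatter) as its step. Compound 4 also stays close to the other two compounds, with a 1.4-fold lower number from compound 2 to compound 4 (0.14 log units; within the scatter) and a 1.4-fold lower number from compound 1 to compound 4 (0.15 log units; within the scatter) as its further steps. Among the compounds shown here, on this saturated ring carbon, a phenyl ring bearing methoxy therefore joins those bearing fluoro, chloro and bromo, and no step among the four compounds goes beyond the scatter.

No measurement at hand offers a reason for this narrow spread. From the compounds shown here alone, whether any group on this carbon can move the number beyond the scatter stays open, for instance a phenyl ring bearing an amine or a carboxylic acid, or a longer chain in place of the ring.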